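Methoxy Enters the Anilino Ring of Compound 1

The source may report more compounds than this note shows. Statements on the series, on what has been measured and on what is new or still open speak of the compounds shown alone.

Within the data shown here, compound 1 `Cc1nc(SCC(=O)Nc2nc(-c3ccc(Cl)cc3)cs2)n(Nc2ccccc2)c1C` holds the lowest number of the two compounds measured so far; in a functional assay on K562 cells (Homo sapiens) for antiproliferative activity, read by sulforhodamine B assay, with a stated time of 48 h (on this read-out higher numbers stand for weaker inhibition of growth and lower numbers for stronger inhibition of growth), compound 1 gives 120 nM. Compound 2 `Cc1ccc(Nn2c(SCC(=O)Nc3nc(-c4ccccc4)cs3)nc(C)c2C)cc1` is built differently in two places at once, and in this assay compound 2 gives 3620 nM, a clearly higher number. These two compounds differ in more than one place, so no single change can be read from that pair. Compound 3 `COc1ccc(Nn2c(SCC(=O)Nc3nc(-c4ccc(Cl)cc4)cs3)nc(C)c2C)cc1` has not been measured yet. It differs from compound 1 by methoxy in place of hydrogen on an aromatic carbon, so the anilino becomes (4-methoxyphenyl)amino. Among the measured compounds shown here, no measured pair shows what this change alone does. The expectation is a modest step toward weaker inhibition of growth, a 2.5-fold higher number from compound 1 to compound 3 (0.40 log units; beyond the scatter), which may or may not exceed the scatter. Compound 3 is therefore estimated at 300 nM, with a range from 80 nM to 1500 nM.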

Compound 3, concentration for 50% growth inhibition: 1580 nM
Compound 3: middle estimate off by 5.3-fold (0.72 log units), on the low side, outside the stated range (above it).
By their numbers in this assay, from the lowest: compound 1; then compound 3; then compound 2.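

The step on this ring can now be read on its own: in this assay, methoxy in place of hydrogen, on an aromatic carbon para to a large group, gives a 13-fold higher number from compound 1 to compound 3 (1.12 log units; beyond the scatter). This position is therefore sensitive to substitution, since a group of only 2 heavy atoms, with no ring and no net charge, clearly moves the number toward weaker inhibition of growth. Among these compounds, nothing measured so far explains why this step is so large.

As far as these compounds go, whether an amine or a hydroxyl on the same carbon would cost as much remains open, as does the effect of methoxy on another carbon of this ring. Compound 2 carries a methyl on this ring but differs from compound 3 in a second place as well, so that pair cannot show how methyl compares with methoxy.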